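Swapping the acetal ring on compound 1 for a piperidine

The source may hold more compounds than are shown below. What is called first, only, known or untested is meant among the compounds shown, and "the series" means these compounds.

Measured so far:
compound 1 `Cc1cc(C)c(S(=O)(=O)N2CCC(C3OCC(C)CO3)CC2)c(C)c1` — > 5000 nM
compound 2 `CC1CCN(C2CCN(S(=O)(=O)c3cccc4cnccc34)CC2)CC1` — 225 nM
compound 3 `CC1CCN(C2CCN(S(=O)(=O)c3ccc(C#N)cc3)CC2)CC1` — 2800 nM

In a functional assay on DLD-1 cells (Homo sapiens) for antiproliferative activity, read by CellTiter-Glo, with a stated time of 72 h (on this read-out lower numbers stand for stronger inhibition and higher numbers for weaker inhibition), compound 1 gives > 5000 nM, which is a limit of the assay and not a number. It sits at the limit of > 5000 nM in this assay, at which 1 of the 3 values shown sits. Within the data shown here, compound 2 gives 225 nM in this assay, and compound 3 gives 2800 nM; the two values show a gap, with compound 2 the lower number, but no step between them is computed here, since the two differ in more than one place.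

Compound 4 `Cc1cc(C)c(S(=O)(=O)N2CCC(N3CCCCC3)CC2)c(C)c1` keeps the core of compound 1 and changes it in one place: a group of 6 heavy atoms (5 carbon, 1 nitrogen; one six-membered non-aromatic ring with 1 hetero atom) in place of a group of 7 heavy atoms (5 carbon, 2 oxygen; one six-membered non-aromatic ring with 2 hetero atoms), on a saturated ring carbon. Compounds 2 and 3 both carry a ring nitrogen on the saturated ring carbon and both give a number in this assay, whereas compound 1, with its oxygen-bearing ring there, gives only a limit. On that basis a shift towards the stronger side is expected for compound 4, though its size cannot be read from a limit and the arylsulfonyl part of compound 4 matches none of compounds 2 and 3.

Compound 4 is expected to give about 3000 nM in this assay, within 800 nM to 10000 nM. The step of an at least 1.6-fold lower number from compound 1 to compound 4 (0.22 log units; that floor lies within the scatter) is the expected one, with a real chance that compound 4 again returns only a limit.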

Compound 4, half-maximal inhibitory concentration: 2200 nM
The estimate for compound 4 lay 1.4-fold (0.13 log units) above the measured number; the range from low to high includes it.
By their numbers in this assay, from the lowest: compound 2; then compounds 4 and 3 (each within the scatter of the next). At a limit, above all of these: compound 1.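

In this assay, the piperidin-1-yl group on the saturated ring carbon gives an at least 2.2-fold lower number from compound 1 to compound 4 (0.35 log units; beyond the scatter), and this is the only step shown at this position with the rest of the core of compound 1 unchanged. Compound 1 stands at a limit of the assay and not at a number, so the full size of the step cannot be read: the limit of > 5000 nM in this assay, at which 1 of the 4 values shown sits. Compound 4 gives the series a measured value for this arylsulfonyl part, a base that compounds 2 and 3 could not provide, since each differs from compound 1 in more than one place.

The compounds shown do not separate the ring nitrogen from the other parts of the swap, and a cyclohexyl or morpholin-4-yl group on the same carbon would tell these apart. Compounds 2 and 3 also differ from compound 4 in more than one place, so the share of the arylsulfonyl part and of the methyl group on their piperidine ring remains unresolved.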